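Working notes: from compound 2 to compound 3

This account rests on a few compounds, and the source may have more. Where it says the series, first, only, none or still open, it means among the compounds named here.

Measured in a functional assay on MCF7 cells (Homo sapiens) for inhibition, read by MTT assay, with a stated time of 48 h; a lower number here means a stronger inhibitor, a higher number a weaker inhibitor:
- compound 1 `COc1ccc(C(c2c[nH]c3ccc(Br)cc23)c2c[nH]c3ccc(Br)cc23)cc1`: 2300 nM
- compound 2 `COc1ccc(C(c2c[nH]c3ccc(Br)cc23)c2c[nH]c3ccc(Br)cc23)cc1OC`: 7800 nM

Compound 2, at 7800 nM, stands highest of the two measured compounds, and compound 1 is its nearest neighbour. The next compound is compound 3 `O=[N+]([O-])c1ccc(C(c2c[nH]c3ccc(Br)cc23)c2c[nH]c3ccc(Br)cc23)cc1`, and the change is 4-nitrophenyl in place of 3,4-dimethoxyphenyl on a saturated chain carbon bound to two aromatic carbons. Among the measured compounds shown here, only one measured step bears on this: a 3.4-fold higher number from compound 1 to compound 2 (0.53 log units; beyond the scatter), which comes with methoxy in place of hydrogen on an aromatic carbon. That step is modest but beyond the scatter. Compound 3 carries no methoxy group, so the step from compound 1 gives a direction, and a lower number is expected in this assay. For the measured compounds named here, no measured compound carries 4-nitrophenyl, so the data say nothing direct about that part of the change, and the range has to stay wide. The expected step is a 2.2-fold lower number from compound 2 to compound 3 (0.34 log units; beyond the scatter), of about the same modest size as the measured one. In this assay, for compound 3 the estimated value is 3600 nM, with 1300 nM to 10000 nM as the expected range.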

Compound 3, half-maximal inhibitory concentration: 3100 nM
For compound 3 the middle estimate is 1.2-fold (0.06 log units) above the measured one; the measured number falls inside the stated range.
By their numbers in this assay, from the lowest: compounds 1 and 3 (each within the scatter of the next); then compound 2.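

Read in this assay, the aromatic ring on the saturated chain carbon bound to two aromatic carbons accepts a nitro group without any loss: a 2.5-fold lower number from compound 2 to compound 3 (0.40 log units; beyond the scatter) comes with 4-nitrophenyl in place of 3,4-dimethoxyphenyl. The second step, a 1.3-fold higher number from compound 1 to compound 3 (0.13 log units; within the scatter), comes with nitro in place of methoxy on an aromatic carbon, so this exchange gives no readable change, and among the three compounds only compound 2 stands apart, with both of its printed steps beyond the scatter. No independent measurement bears on the cause of either step.

The compounds shown leave open whether an amine or a carboxylic acid on this aromatic ring would keep the numbers in the same range, or move them well away from it. They also leave open how much of the result depends on the ring itself, which a simple alkyl chain on the same saturated carbon would test, and whether chlorine in place of bromine on the shared core would shift the whole series.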